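The compounds below may be only part of what the source reports. "The series", "measured", "known", "first", "only" and "open" are said of these compounds alone.

Working notes on the series. Compound 1 `CN(C)CCCCOc1ccccc1/C=C/c1cccc(Cl)c1` stands second highest of the three numbers in a functional assay on the whole organism with Mus musculus as the target, at a dose of 50 mg/kg by the oral route (on this read-out lower numbers stand for less inhibition and higher numbers for more inhibition at the one dose given (going by the name of the read-out)), where compound 1 gives 23.9%. Compound 2 `CN(C)CCCCOc1ccccc1/C=C/c1ccc(Cl)cc1` gives 62.5%, and compound 3 `CN(C)CCCCOc1ccccc1/C=C/c1cccc(F)c1` gives 12.5%. The measured steps are a number 38.6 percentage points higher from compound 1 to compound 2 (beyond the scatter), a number 11.4 percentage points lower from compound 1 to compound 3 (beyond the scatter) and a number 50 percentage points lower from compound 2 to compound 3 (beyond the scatter). Compound 4 `CN1CCN(CCCCOc2ccccc2/C=C/c2cccc(Cl)c2)CC1` differs from compound 1 by 4-methylpiperazin-1-yl in place of dimethylamino on a saturated chain carbon, four bonds along the chain from an oxygen on an aromatic ring. For the measured compounds named here, none of the measured steps touches this part of the structure: all three exchange one halogen-substituted phenyl for another and leave the amine end of the chain unchanged. No measured step therefore bears on the change from compound 1 to compound 4, and its size and direction cannot be read from the numbers shown. The working expectation is no step beyond the scatter, set with a wide range to reflect the absence of any comparable precedent. For compound 4 the expected step is a number 0.1 percentage points higher from compound 1 to compound 4 (within the scatter). Compound 4 is expected at 24%, within 5% to 50%.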

Compound 4, a percentage reported as inhibition, in the whole organism at one dose (the size of the read-out at that dose, not a potency): 50%
Beside the measured number, compound 4's estimate is 26 percentage points below it; the range from low to high includes it.
By their numbers in this assay, from the lowest: compound 3; then compound 1; then compound 4; then compound 2.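

In this assay, the amine end of the chain is a position that moves the read-out: 4-methylpiperazin-1-yl in place of dimethylamino gives a number 26.1 percentage points higher from compound 1 to compound 4 (beyond the scatter). For the compounds shown here, the earlier steps only exchanged one halogen-substituted phenyl for another, so this is the first sign that the read-out also responds to a change on a saturated chain carbon, four bonds along the chain from an oxygen on an aromatic ring. Nothing available accounts for the size or direction of this step.

The compounds shown leave open whether the same exchange raises the number when the 4-chlorophenyl of compound 2 or the 3-fluorophenyl of compound 3 is present. They also leave open whether the ring alone or the second nitrogen goes with the change, which piperidin-1-yl or morpholin-4-yl at the same place would address.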